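Compound 2 Gives Up Its 4-Chlorophenyl Group

A few compounds are considered here, and "the series" means these few. Any claim that something is new, unique, unknown or untested is made for them only; others in the source may bear on it.

In an ADME assay on Vero cells (Chlorocebus sabaeus) for cytotoxicity, read by MTT assay, with a stated time of 48 h (on this read-out higher numbers stand for lower toxicity in this test and lower numbers for higher toxicity in this test), compound 1 (`CN(C)c1ccc(C(C)(C)NC(=O)c2ccc([N+](=O)[O-])o2)cc1`) gives 79000 nM as its half-maximal cytotoxic concentration. In this assay compound 2 (`CC(C)(NC(=O)c1ccc([N+](=O)[O-])o1)c1ccc(-c2ccc(Cl)cc2)cc1`) gives only > 140000 nM as a limit of the assay and not as a number. Compound 2 thus stands at the limit of > 140000 nM in this assay, at which 1 of the 2 values shown sits, and has no exact place on the scale.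

Compound 3 (`COc1ccc(OCc2ccc(C(C)(C)NC(=O)c3ccc([N+](=O)[O-])o3)cc2)cc1`) carries (4-methoxyphenoxy)methyl in place of 4-chlorophenyl on an aromatic carbon of the shared core. Among the compounds with values here, one measured step bears on this change, with dimethylamino giving way to 4-chlorophenyl on the same carbon. Within the data shown here, with that step as the only guide (an at least 1.7-fold higher number from compound 1 to compound 2 (0.24 log units; that floor lies within the scatter)) no step beyond the scatter is expected in this assay and no direction is favoured. The estimated step is an at least 1.4-fold lower number from compound 2 to compound 3 (0.14 log units; that floor lies within the scatter) on this expectation. For compound 3 the expected value is 100000 nM with an estimated range from 40000 nM to 200000 nM and a report of a limit alone would be no surprise.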

Compound 3, half-maximal cytotoxic concentration: > 120000 nM
Compound 3 gave a limit, no number (the forecaster's own chance of this, stated with the estimate: 50%); middle value at least 1.2-fold (0.07 log units) away from the limit.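

The position takes a second large group without a number appearing: with (4-methoxyphenoxy)methyl on this aromatic carbon, para to a large group, compound 3 in this assay is reported only as a limit of the assay, > 120000 nM. The change is not a small one on paper, since 10 heavy atoms with 2 hydrogen-bond acceptors enter where 7 heavy atoms with none leave, yet the result is again a limit, as it was for 4-chlorophenyl. Measured from the dimethylamino compound, the reading is an at least 1.5-fold higher number from compound 1 to compound 3 (0.18 log units; that floor lies within the scatter), so the floor of this step, like that of the earlier one, gives no evidence of a real change.

Going by these compounds, the step between the two limits cannot be read, and whether 4-chlorophenyl and (4-methoxyphenoxy)methyl differ at all in this test stays open. The compounds shown also leave open how this carbon would respond to a carboxylic acid or a longer alkyl chain, and whether any such group would give a number rather than a limit.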